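A few compounds are considered here, and "the series" means these few. Any claim that something is new, unique, unknown or untested is made for them only; others in the source may bear on it.

Measured in a functional assay on HUVEC cells (Homo sapiens); a lower number here means that less compound is needed, a higher number that more compound is needed for the effect:
Compound 1 `COC1=C(C)C(=O)/C(=C(O)/C=C/c2cccc(OC)c2)C(=O)C1(C)C`: < 4 ug/mL
Compound 2 `COC1=C(C)C(=O)/C(=C(O)/C=C/c2c(C)cccc2C)C(=O)C1(C)C`: < 4 ug/mL

Compound 2 stands at < 4 ug/mL, which is a limit of the assay and not a number. Compound 1, at < 4 ug/mL, is also reported only as a limit. Neither compound therefore has an exact position on the scale, and the limit of < 4 ug/mL in this assay, at which 2 of the 2 values shown sit, is all that can be said of the pair.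

Compound 3 `COC1=C(C)C(=O)/C(=C(O)/C=C/c2cc(C)cc(C)c2)C(=O)C1(C)C` has 3,5-dimethylphenyl in place of 2,6-dimethylphenyl on a double-bonded chain carbon bound to a double-bonded chain carbon.

Going by the values given here, the one measured step bearing on this change is a step that the two limits leave unreadable from compound 1 to compound 2, so it offers no size to carry over. With compound 1 and compound 2 both sitting at the limit of < 4 ug/mL in this assay, at which 2 of the 2 values shown sit, no step beyond the scatter is expected in this assay, in either direction. The expected step is a step that the limit leaves unreadable from compound 2 to compound 3. For compound 3 the estimated value is 2 ug/mL, with an expected range from 0.6 ug/mL to 5 ug/mL.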

Compound 3, concentration for half-maximal effect: < 4 ug/mL
Compound 3 ended at the assay's limit; the forecaster's own chance of this, stated with the estimate: 65%; the middle value does not contradict the limit.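

Compound 1, compound 2 and compound 3 are all reported only as a limit and not as a number, so no step among them can be read: the limit of < 4 ug/mL in this assay, at which 3 of the 3 values shown sit.

From the compounds shown here alone, whether 3-methoxyphenyl, 2,6-dimethylphenyl and 3,5-dimethylphenyl differ at all in the amount of compound needed, and by how much, stays open.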